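Replacing Phenyl with Cyclohexylmethyl: Expected Solubility Shift

The compounds below may be only part of what the source reports. "The series", "measured", "known", "first", "only" and "open" are said of these compounds alone.

Measured so far:
Compound 1, `COc1ccc(F)cc1CNCCCNc1ccnc2cc(Cc3ccc(F)cc3)ccc12`: 4200 nM
Compound 2, `COc1ccc(F)cc1CNCCCNc1ccnc2cc(Cc3ccc(C#N)cc3)ccc12`: 4200 nM
Compound 3, `COc1ccc(F)cc1CNCCCNc1ccnc2cc(-c3ccccc3)ccc12`: 32000 nM

These values come from a physicochemical assay for solubility, with a stated time of 18 h, at pH 7.4; on this read-out higher numbers stand for higher solubility and lower numbers for lower solubility. Compound 3 gives the highest number of the three; in this assay the step from compound 1 is a 7.6-fold higher number from compound 1 to compound 3 (0.88 log units; beyond the scatter) and the step from compound 2 is a 7.6-fold higher number from compound 2 to compound 3 (0.88 log units; beyond the scatter), while no change at the digits printed from compound 1 to compound 2 (within the scatter). Compound 4, `COc1ccc(F)cc1CNCCCNc1ccnc2cc(CC3CCCCC3)ccc12`, has not yet been measured. The change is cyclohexylmethyl in place of phenyl on an aromatic carbon. The entering group, like 4-fluorobenzyl and 4-cyanobenzyl in compounds 1 and 2, is a ring joined through a single carbon, though here the ring is non-aromatic, so the step is expected to run opposite to those two rises, giving an estimated 6.4-fold lower number from compound 3 to compound 4 (0.81 log units; beyond the scatter). Compound 4 is therefore expected at about 5000 nM, within 1500 nM to 16000 nM.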

Compound 4, solubility: 4200 nM
Estimate against measurement, compound 4: 1.2-fold (0.08 log units) above, within the range that was stated.
By their numbers in this assay, from the lowest: compounds 1, 2 and 4 (each within the scatter of the next); then compound 3.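

In this assay, replacing the 4-fluorophenyl or 4-cyanophenyl ring with cyclohexyl on the same saturated carbon gives no change at the digits printed from compound 1 to compound 4 (within the scatter) and no change at the digits printed from compound 2 to compound 4 (within the scatter). Among these compounds, an aromatic or non-aromatic ring on that carbon therefore makes no visible difference, while compound 3, with its phenyl joined directly to the core, stands apart, as shown by a 7.6-fold lower number from compound 3 to compound 4 (0.88 log units; beyond the scatter).

No measurement here explains this pattern. Cyclohexyl joined directly to the core, or a longer chain such as 2-phenylethyl, would help show whether the ring or the linking carbon matters more.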